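One stereocentre redrawn: notes on compound 4

The compounds below may be only part of what the source reports. "The series", "measured", "known", "first", "only" and "open" are said of these compounds alone.

Values in an ADME assay on MDCK cells (Canis lupus familiaris) for permeability, in the apical to basolateral direction (a lower number here means that the compound crosses the layer more slowly, a higher number that the compound crosses the layer faster), so far
- compound 1 `Cn1cnc(C(=O)N(Cc2ccc(F)c(C(F)(F)F)c2)[C@H]2C[C@H]3CNC[C@H]3C2)c1` gives 2.1 10^-6 cm/s 
- compound 2 `CC(C)Oc1cccc(CN(C(=O)c2cn(C)cn2)[C@H]2C[C@H]3CNC[C@H]3C2)c1` gives 2.2 10^-6 cm/s 
- compound 3 `COc1ccc(CN(C(=O)c2cn(C)cn2)[C@H]2C[C@H]3CNC[C@H]3C2)cc1OC1CCCC1` gives 0.291 10^-6 cm/s 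

In this assay compound 1 gives 2.1 10^-6 cm/s and compound 2 gives 2.2 10^-6 cm/s, two values within the scatter of each other. Compound 3 gives 0.291 10^-6 cm/s on the same read-out. The gap between compound 1 and compound 3 lies beyond the scatter, with compound 3 the lower of the two.

Compound 4 `Cn1cnc(C(=O)N(Cc2ccc(F)c(C(F)(F)F)c2)[C@@H]2C[C@H]3CNC[C@H]3C2)c1` is the next to consider. It differs from compound 1 as follows (the two compounds have the same atoms and bonds and differ only in configuration as drawn: 1 of 3 stereo elements differ; a stereocentre at a saturated ring carbon is drawn r in compound 1 and s in compound 4): the two compounds have the same atoms and bonds, and a stereocentre at a saturated ring carbon is drawn r in compound 1 and s in compound 4.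

Among the compounds with values here, no measured pair isolates a change of configuration, so the data give no size for such a step. The expectation therefore starts from compound 1 at 2.1 10^-6 cm/s and favours no direction, with no step beyond the scatter expected in this assay for this pair. The estimated change is a 1.1-fold lower number from compound 1 to compound 4 (0.02 log units; within the scatter) on this read-out. The estimate for compound 4 is 2 10^-6 cm/s as a middle value, with an expected range from 0.7 10^-6 cm/s to 5 10^-6 cm/s around it.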

Compound 4, apparent permeability: 0.2 10^-6 cm/s
Estimate against measurement, compound 4: 10-fold (1.00 log units) above; measured number outside the range, below it.
By their numbers in this assay, from the lowest: compounds 4 and 3 (each within the scatter of the next); then compounds 1 and 2 (each within the scatter of the next).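

In this assay the configuration at this saturated ring carbon is far from neutral: redrawing it from r to s gives an 11-fold lower number from compound 1 to compound 4 (1.02 log units; beyond the scatter). Compounds 1, 2 and 3 all carry the same drawn configuration at this carbon, so they gave no reading of this change, and this pair gives the first size for it. The step can be assigned to this one stereocentre alone, because nothing else separates the two structures: the fact that compounds 1 and 4 differ only in the configuration as drawn

This single pair leaves open whether a step of this size holds for compound 2 or compound 3, or for a change at either of the other two stereo elements. Going by these compounds, how a nitrile or a carboxylic acid in place of the trifluoromethyl would read in this assay under either configuration also remains open.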